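Hydrogen for methyl on the thioamide nitrogen

The compounds below may be only part of what the source reports. "The series", "measured", "known", "first", "only" and "open" are said of these compounds alone.

The study starts from compound 3 `CNC(=S)N1CC(C)C(c2ccc(OC)cc2)=N1`. In an in vitro assay on cells for inhibition of Amine oxidase [flavin-containing] A (Homo sapiens), read by Amplex Red, with a stated time of 15 min, tested at 100 uM (on this read-out lower numbers stand for less inhibition and higher numbers for more inhibition at the one concentration tested (going by the name of the read-out)), compound 3 gives "not active" (no number reported), so no single number stands for it. Compound 1 `COc1ccc(C2=NN(C(N)=S)CC2)cc1` is the one further entry that also stands without a single number, and in this assay compound 1 gives "not active" (no number reported). Only compound 2 `CC1CN(C(N)=S)N=C1c1ccc(F)cc1` carries a number: in this assay compound 2 gives 40%. Compound 4 `COc1ccc(C2=NN(C(N)=S)CC2C)cc1` has not yet been measured. Against compound 3 the change is hydrogen in place of methyl on an amide-type nitrogen. For the measured compounds named here, no step between two measured compounds shows this change, so its size in this assay cannot be read from the numbers; the step from compound 3 to compound 4 is expected to be small, with no clear direction and possibly none beyond the scatter, because compound 3 gives "not active" (no number reported) and the only numbered compound, compound 2, differs in more than one place. Compound 4 is therefore expected to give about 15% in this assay, within a range from 0% to 40%.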

Compound 4, a percentage reported as inhibition, at one concentration (the size of the read-out at that concentration, not a potency): 40%
Beside the measured number, compound 4's estimate is 25 percentage points below it; the range from low to high includes it.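

In this assay compound 4, with amino on the amide-type nitrogen, gives 40% and compound 3, with methylamino there, gives "not active" (no number reported) in the same read-out; the size of this change cannot be read, since one of the two entries has no number. Methoxy in place of fluoro on an aromatic carbon shows no change at the digits printed from compound 2 to compound 4 (within the scatter) while compound 4 keeps the hydrogen on that nitrogen. Nothing supplied here accounts for these results.

As far as these compounds go, whether a longer chain such as ethyl on that nitrogen would read like the methylamino of compound 3 stays open. Also open, from the compounds shown here alone, is how a carbonyl in place of the thiocarbonyl would read, and how an amine or a carboxylic acid on the aromatic carbon would compare with methoxy and fluoro.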